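The source may hold more compounds than are shown below. What is called first, only, known or untested is meant among the compounds shown, and "the series" means these compounds.

Compound 1 `CC(C)C[C@H](N)c1cc(C(F)(F)F)ccc1N1CCN(C(=O)CC(C)C(=O)c2ccc(Cl)cc2)CC1` is the reference point here. In an assay on HEK293 cells for displacement of a labelled ligand from Melanocortin receptor 4 (Homo sapiens) (on this read-out higher numbers stand for weaker inhibition and lower numbers for stronger inhibition), compound 1 gives 1100 nM, the lowest number among the three compounds that have been measured, and so the strongest binding shown. Two neighbours replace the same side chain on the saturated chain carbon bound to the carbonyl carbon. Compound 2 `CC(C)C[C@H](N)c1cc(C(F)(F)F)ccc1N1CCN(C(=O)COc2ccc(Cl)cc2)CC1` gives 2900 nM in this assay, a step of a 2.6-fold higher number from compound 1 to compound 2 (0.42 log units; beyond the scatter). Compound 3 `CC(C)C[C@H](N)c1cc(C(F)(F)F)ccc1N1CCN(C(=O)CNc2ccccc2)CC1` gives 3600 nM, a step of a 3.3-fold higher number from compound 1 to compound 3 (0.51 log units; beyond the scatter), while the gap from compound 2 to compound 3 is only a 1.2-fold higher number from compound 2 to compound 3 (0.09 log units; within the scatter).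

Compound 4 `CC(C)C[C@H](N)c1cc(C(F)(F)F)ccc1N1CCN(C(=O)CCC(=O)c2ccc(Cl)cc2)CC1` is not yet measured. Its difference from compound 1 is small: hydrogen in place of methyl on a saturated chain carbon bound to a carbonyl carbon and a saturated chain carbon. Seen one bond further out, the 1-((4-chlorophenyl)carbonyl)ethyl becomes ((4-chlorophenyl)carbonyl)methyl, the rest staying as in compound 1. The two measured steps from compound 1 swapped out the whole side chain and both weakened binding modestly; neither tests the removal of a methyl alone, so they set only a rough ceiling. Compound 4 is therefore expected to sit close to compound 1, with at most a slight rise in the number, a step of a 1.4-fold higher number from compound 1 to compound 4 (0.13 log units; within the scatter). The estimate for compound 4 in this assay is 1500 nM, with a likely range from 700 nM to 3500 nM.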

Compound 4, inhibition constant: 820 nM
Compound 4: middle estimate off by 1.8-fold (0.26 log units), on the high side, within the range that was stated.
By their numbers in this assay, from the lowest: compounds 4 and 1 (each within the scatter of the next); then compounds 2 and 3 (each within the scatter of the next).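

Taking the methyl off the side chain of compound 1 is the first change here that leaves the rest of that chain intact, and in this assay it gives a 1.3-fold lower number from compound 1 to compound 4 (0.13 log units; within the scatter) with no shift beyond the scatter, so binding at this level does not depend on that methyl. The advantage over the other two side chains also survives without the methyl, as the steps of a 3.5-fold lower number from compound 2 to compound 4 (0.55 log units; beyond the scatter) and a 4.4-fold lower number from compound 3 to compound 4 (0.64 log units; beyond the scatter) show, which ties that advantage to the rest of the ((4-chlorophenyl)carbonyl)methyl chain rather than to the methyl itself. Nothing among the available data explains these differences in binding.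

The compounds shown leave open whether an ethyl group or a hydroxyl group at this saturated chain carbon would be tolerated as well as hydrogen and methyl are. They also leave open whether a longer chain carrying the same 4-chlorophenyl carbonyl, or an amine in place of that carbonyl, would hold, improve or lose this level of binding.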